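Phenyl replacing aminopyrazinyl on a fused aromatic core

The compounds below may be only part of what the source reports. "The series", "measured", "known", "first", "only" and "open" are said of these compounds alone.

Measured compounds:
- compound 1 `Cc1nc2c3ccccc3ccc2c2nc3c(ccc4ccccc43)c(-c3nccnc3N)c12`: 1210 nM
- compound 2 `Cc1nc2c3ccccc3ccc2c2nc3c(ccc4ccccc43)c(-c3cc([N+](=O)[O-])ccc3N)c12`: 5770 nM
- compound 3 `Cc1nc2c3ccccc3ccc2c2nc3c(ccc4ccccc43)c(-c3ccccc3S)c12`: 3190 nM

Going by the values given here, in a functional assay on HeLa cells (Homo sapiens) for cytotoxicity, read by MTT assay, with a stated time of 48 h (on this read-out lower numbers stand for stronger inhibition and higher numbers for weaker inhibition), compound 1 gives 1210 nM, the lowest of the three numbers measured so far. Compound 3 comes nearest, and the change from compound 1 to compound 3 gave a 2.6-fold higher number from compound 1 to compound 3 (0.42 log units; beyond the scatter). Compound 2 lies furthest off, with a 4.8-fold higher number from compound 1 to compound 2 (0.68 log units; beyond the scatter). Between those two, a 1.8-fold lower number from compound 2 to compound 3 (0.26 log units; within the scatter).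

Compound 4 `Cc1nc2c3ccccc3ccc2c2nc3c(ccc4ccccc43)c(-c3ccccc3)c12` has not yet been measured in this assay. It differs from compound 1 by phenyl in place of 3-aminopyrazin-2-yl on an aromatic carbon. The two measured steps that bear on this one both start from compound 1 and exchange the same 3-aminopyrazin-2-yl for a different carbon ring on the same aromatic carbon; both of them gave higher numbers, one modest and one somewhat larger. A phenyl carries none of the features counted for the group it replaces, so compound 4 is expected to behave more like compound 2 and compound 3 than like compound 1, with a modest rise in the number. Compound 4 is therefore estimated at 3500 nM, within a range of 1500 nM to 8000 nM, which would mean an expected step of a 2.9-fold higher number from compound 1 to compound 4 (0.46 log units; beyond the scatter).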

Compound 4, half-maximal inhibitory concentration: > 80000 nM
Compound 4 was reported as a limit (the forecaster's own chance of this, stated with the estimate: 5%); middle value at least 22-fold (1.35 log units) away from the limit.
By their numbers in this assay, from the lowest: compound 1; then compounds 3 and 2 (each within the scatter of the next). At a limit, above all of these: compound 4.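

In this assay, compound 4 gives a limit rather than a number: the limit of > 80000 nM in this assay, at which 1 of the 4 values shown sits. The bare phenyl stands well apart from every other ring on this aromatic carbon, with an at least 66-fold higher number from compound 1 to compound 4 (1.82 log units; beyond the scatter), an at least 13-fold higher number from compound 2 to compound 4 (1.14 log units; beyond the scatter) and an at least 25-fold higher number from compound 3 to compound 4 (1.39 log units; beyond the scatter), all large, whereas the earlier exchanges at this position moved the number only modestly or within the scatter. The last of these steps is only hydrogen in place of sulfanyl, so among these four compounds a carbon-only ring on this carbon keeps a measurable number when it carries a substituent, as compounds 2 and 3 do, and the one ring without a substituent, in compound 4, does not.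

The compounds shown leave open whether a single amine on the phenyl, as in 2-aminophenyl, would be enough to restore a measurable number, or whether a hydroxyl in place of the sulfanyl would serve equally well. They also leave open how a pyrazin-2-yl without its amine would compare, which would separate the ring nitrogens of compound 1 from its amino group.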